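Swapping methyl for phenyl on the acylguanidine chain

A few compounds are considered here, and "the series" means these few. Any claim that something is new, unique, unknown or untested is made for them only; others in the source may bear on it.

Compound 2 `CC(CC(=O)/N=C(\N)NCCCc1cn[nH]c1)c1ccccc1`: 3800 nM
Compound 1 `N/C(=N\C(=O)CC(c1ccccc1)c1ccccc1)NCCCn1ccnc1`: 2340 nM

In an assay on ileum for antagonist activity at histamine H1 receptor (Cavia porcellus), with a stated time of 15 min (a lower number here means tighter binding, a higher number weaker binding), compound 2 gives 3800 nM, the higher of the two numbers, while compound 1 gives 2340 nM; the gap between them lies within the scatter. Compound 3 `N/C(=N\C(=O)CC(c1ccccc1)c1ccccc1)NCCCc1cn[nH]c1` differs from compound 2 by phenyl in place of methyl on a saturated chain carbon bound to an aromatic carbon and a saturated chain carbon. Going by the values given here, no step of this kind has been measured here. The expectation is a small change, if any, in this assay, so the step from compound 2 to compound 3 is estimated at a 1.5-fold lower number from compound 2 to compound 3 (0.18 log units; within the scatter). Compound 3 is expected to give 2500 nM, within 800 nM to 8000 nM.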

Compound 3, dissociation constant: 2570 nM
Beside the measured number, compound 3's estimate is 1.0-fold (0.01 log units) below it, within the range that was stated.
By their numbers in this assay, from the lowest: compounds 1, 3 and 2 (each within the scatter of the next).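

Putting phenyl in place of methyl on this saturated chain carbon gives a 1.5-fold lower number from compound 2 to compound 3 (0.17 log units; within the scatter) in this assay and so leaves the number within the scatter, even with a whole aromatic ring entering. Placing 1H-pyrazol-4-yl where 1H-imidazol-1-yl stood, on the saturated chain carbon three bonds along the chain from an amine nitrogen, gives a 1.1-fold higher number from compound 1 to compound 3 (0.04 log units; within the scatter) and also stays within the scatter. No measured evidence accounts for either result.

On these data alone, whether an amine or a carboxylic acid on that same chain carbon would move the number beyond the scatter stays open. So does the effect of a longer chain leading to the 1H-pyrazol-4-yl.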